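A few compounds are considered here, and "the series" means these few. Any claim that something is new, unique, unknown or untested is made for them only; others in the source may bear on it.

Measured so far in a physicochemical assay for solubility, read by HPLC, in phosphate buffer, measured as kinetic solubility, at pH 7.4; on this read-out lower numbers stand for lower solubility and higher numbers for higher solubility:
- compound 1 `CCCC(=O)c1cc(-c2ccc(S(N)(=O)=O)cc2)n(-c2ccc(Cl)cc2)n1`: 25800 nM
- compound 2 `CCC(=O)c1cc(-c2ccc(S(N)(=O)=O)cc2)n(-c2ccccc2)n1`: 47200 nM

These two values lie within the usual scatter of each other, so compound 1 stands level with compound 2 on the numbers available. The two compounds do not differ in one place only, and the series therefore offers no measured single change to calibrate against.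

The next compound is compound 3 `NS(=O)(=O)c1ccc(-c2cc(C(=O)N3CC4CC4C3)nn2-c2ccc(Cl)cc2)cc1`, which keeps the core of compound 1 and alters one group, on a carbonyl carbon: a group of 6 heavy atoms (5 carbon, 1 nitrogen; one three-membered non-aromatic ring of carbon only, one five-membered non-aromatic ring with 1 hetero atom) in place of a group of 3 heavy atoms (3 carbon; no ring), on a carbonyl carbon. The propyl group, with no ring, gives way to a larger group holding a three-membered and a five-membered non-aromatic ring.

Going by the values given here, no measured step covers a change of this kind, so the expectation is loose. In this assay, a modest step to a lower number is expected, of about the size of the scatter, and a result level with compound 1 would be unremarkable. The estimated change is a 1.7-fold lower number from compound 1 to compound 3 (0.24 log units; within the scatter).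

For compound 3, the estimated value is 15000 nM, with an expected range from 4000 nM to 45000 nM.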

Compound 3, solubility: 36600 nM
The estimate for compound 3 lay 2.4-fold (0.39 log units) below the measured number; low and high end bracket the measured number.
By their numbers in this assay, from the lowest: compounds 1, 3 and 2 (each within the scatter of the next).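

Notes on the carbonyl position: on a carbonyl carbon whose other neighbours are aromatic carbon, replacing propyl with the group holding a three-membered and a five-membered non-aromatic ring gives, in this assay, a 1.4-fold higher number from compound 1 to compound 3 (0.15 log units; within the scatter), the first single change that can be read in this series. Compound 3 therefore stands level with compound 1, and at this place the larger group, with its 6 heavy atoms in place of 3, produces no step beyond the scatter. No measurement is available that bears on the reason for this result.

This is a single change at a single place, and it leaves open whether a carbonyl carbon carrying a morpholine ring, an open-chain amine or a longer chain would also stay within the scatter of compound 1, or whether any group here gives a step beyond it. The series also still lacks a single change that connects compound 2 to compound 1 or compound 3, so the groups that separate compound 2 from those compounds remain unresolved one by one.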